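From compound 3 to compound 4: adding hydroxymethyl

The compounds below may be only part of what the source reports. "The series", "measured", "known", "first", "only" and "open" are said of these compounds alone.

In a functional assay for inhibition, read by fluorescence and spectrophotometry, with a stated time of 30 h (a lower number here means a stronger inhibitor, a higher number a weaker inhibitor), compound 1 (`COc1ccc(-c2cc(=O)c3ccc(OCCCCN4CCC(C)CC4)cc3o2)cc1`) gives 48200 nM, compound 2 (`COc1ccc(-c2cc(=O)c3ccc(OCCCCCCN4CCC(C)CC4)cc3o2)cc1`) gives 57200 nM and compound 3 (`COc1ccc(-c2cc(=O)c3ccc(OCCCCCCCN4CCC(C)CC4)cc3o2)cc1`) gives 61600 nM. Compound 3 therefore cannot be separated from compound 1 or compound 2. The steps of a 1.2-fold higher number from compound 1 to compound 2 (0.07 log units; within the scatter), a 1.3-fold higher number from compound 1 to compound 3 (0.11 log units; within the scatter) and a 1.1-fold higher number from compound 2 to compound 3 (0.03 log units; within the scatter) all lie within the scatter, and each alters only the chain.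

Compound 4 (`COc1ccc(-c2cc(=O)c3ccc(OCCCCCCCN4CCC(CCO)CC4)cc3o2)cc1`) keeps the chain of compound 3 and carries hydroxymethyl in place of hydrogen on a saturated chain carbon bound to a saturated ring carbon, which turns 4-methylpiperidin-1-yl into 4-(2-hydroxyethyl)piperidin-1-yl (hydroxymethyl in place of hydrogen on a saturated chain carbon bound to a saturated ring carbon). Going by the values given here, no measured step alters this group, so the series offers no direct precedent, and the range must stay wide. With no direction indicated, no step beyond the scatter is expected, and the expected step is a 1.1-fold lower number from compound 3 to compound 4 (0.05 log units; within the scatter). For compound 4 the estimated value is 55000 nM, with an expected range of 25000 nM to 100000 nM.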

Compound 4, half-maximal inhibitory concentration: 52700 nM
The estimate for compound 4 lay 1.0-fold (0.02 log units) above the measured number; measured number inside the range.
By their numbers in this assay, from the lowest: compounds 1, 4, 2 and 3 (each within the scatter of the next).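

In this assay the change at this position, hydroxymethyl in place of hydrogen on a saturated chain carbon bound to a saturated ring carbon, gives a step within the scatter (a 1.2-fold lower number from compound 3 to compound 4 (0.07 log units; within the scatter)), so on this chain 4-(2-hydroxyethyl)piperidin-1-yl cannot be separated from 4-methylpiperidin-1-yl. The steps that change the chain and this group together are also within the scatter (a 1.1-fold lower number from compound 2 to compound 4 (0.04 log units; within the scatter); a 1.1-fold higher number from compound 1 to compound 4 (0.04 log units; within the scatter)), so the combined change separates nothing either. No supporting data bear on this result.

Open, on these data alone, is whether a carboxylic acid or a primary amine in place of the hydroxymethyl would give a step beyond the scatter. Also open, as far as these compounds go, is how 4-(2-hydroxyethyl)piperidin-1-yl reads on the shorter chains of compound 1 and compound 2.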